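This account rests on a few compounds, and the source may have more. Where it says the series, first, only, none or still open, it means among the compounds named here.

Measured in an ADME assay on HepG2 cells (Homo sapiens) for cytotoxicity, read by luminescence, CellTiter-Glo and ATP content, with a stated time of 72 h; a lower number here means that less compound is needed, a higher number that more compound is needed for the effect:
- compound 1 `COc1ccc(F)cc1CNCCCNc1ccnc2cc(Cc3ccc(F)cc3Cl)ccc12`: 2460 nM
- compound 2 `COc1cccc(CNCCCNc2ccnc3cc(Cc4ccc(F)cc4)ccc23)c1O`: 4780 nM
- compound 3 `COc1ccc(-c2ccc3c(NCCCNCc4cc(F)ccc4OC)ccnc3c2)cc1`: 5960 nM

Compound 3 and compound 2 agree within the usual scatter. Within the data shown here, the one measured step that reaches this pair is a 2.4-fold higher number from compound 1 to compound 3 (0.38 log units; beyond the scatter), and it lies beyond the scatter.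

Compound 4 `COc1ccc(F)cc1CNCCCNc1ccnc2cc(Cc3ccc(F)cc3)ccc12`, not yet measured, follows from compound 3 by 4-fluorobenzyl in place of 4-methoxyphenyl on an aromatic carbon. The measured step bears on this change most directly, since it put 4-methoxyphenyl at the same place where a benzyl group had stood. The step to compound 4 runs the opposite way, and the entering group differs from the 2-chloro-4-fluorobenzyl of compound 1 by the missing chloro only. Compound 2 also carries 4-fluorobenzyl and gives 4780 nM, but it differs elsewhere in the molecule, so it is a looser guide and tempers the expectation.

A modest drop in the number is therefore expected in this assay, and it may not clear the scatter. The expected change is a 1.8-fold lower number from compound 3 to compound 4 (0.24 log units; within the scatter). For compound 4 the estimate is 3400 nM, with an expected range from 1800 nM to 6200 nM.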

Compound 4, half-maximal effective concentration: 3530 nM
The estimate for compound 4 lay 1.0-fold (0.02 log units) below the measured number; the measured number falls inside the stated range.
By their numbers in this assay, from the lowest: compounds 1, 4, 2 and 3 (each within the scatter of the next, the first and the last beyond it).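

In this assay, among these compounds, the exchange at this aromatic carbon gives a 1.7-fold lower number from compound 3 to compound 4 (0.23 log units; within the scatter) for 4-fluorobenzyl in place of 4-methoxyphenyl, and a 1.4-fold higher number from compound 1 to compound 4 (0.16 log units; within the scatter) for hydrogen in place of chloro on the benzyl ring, so compound 4 is not separated from either neighbour, even though the one step beyond the scatter remains a 2.4-fold higher number from compound 1 to compound 3 (0.38 log units; beyond the scatter) for the 4-methoxyphenyl group in place of 2-chloro-4-fluorobenzyl. The other end of the molecule adds no separation at this level either, with a 1.4-fold lower number from compound 2 to compound 4 (0.13 log units; within the scatter) for 5-fluoro-2-methoxyphenyl in place of 2-hydroxy-3-methoxyphenyl on the saturated chain carbon bound to an amine nitrogen. Nothing measured here explains any of these steps.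

Across these four compounds, the number stays within a narrow band, and only the two ends of that band are separated. On these data alone, it remains open whether a group of another kind at this aromatic carbon, such as a carboxylic acid or a primary amine, would move the number clearly beyond the scatter from compound 4, and whether a longer chain would do so.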